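The compounds below may be only part of what the source reports. "The series", "measured", "known", "first", "only" and "open" are said of these compounds alone.

Measured so far:
Compound 1 `CO[C@@H]1[C@H](N(C)c2ncc(-c3c[nH]c4ccc(F)cc34)s2)C[C@H]2O[C@]1(C)n1c3ccccc3c3c4c(c5c6ccccc6n2c5c31)C(=O)NC4`. In an ADME assay on PBMC cells (Homo sapiens) for cytotoxicity, read by CellTiter-Glo, with a stated time of 72 h (a higher number here means a weaker inhibitor, a lower number a stronger inhibitor), compound 1 gives > 10000 nM, which is a limit of the assay and not a number.
Compound 2 `CO[C@@H]1[C@H](N(C)c2ncc(-c3c[nH]c4ccc(Cl)cc34)s2)C[C@H]2O[C@]1(C)n1c3ccccc3c3c4c(c5c6ccccc6n2c5c31)C(=O)NC4`. In this assay compound 2 gives > 10000 nM, again only a limit.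
Compound 3 `CO[C@@H]1[C@H](N(C)c2ncc(-c3c[nH]c4ccc(F)cc34)s2)C[C@H]2O[C@]1(C)n1c3ccccc3c3c4c(c5c6cc(Br)ccc6n2c5c31)C(=O)NC4`. In this assay compound 3 gives > 10000 nM, also only a limit.

Compound 2 differs from compound 1 by chloro in place of fluoro on an aromatic carbon. The step that the two limits leave unreadable from compound 1 to compound 2 cannot be sized, because both values sit at the limit of > 10000 nM in this assay, at which 3 of the 3 values shown sit. Compound 3 differs from compound 1 in its core by bromo in place of hydrogen on an aromatic carbon, and a step that the two limits leave unreadable from compound 1 to compound 3 is equally unreadable for the same reason, both values resting at the limit of > 10000 nM in this assay, at which 3 of the 3 values shown sit. No ordering among compounds 1, 2 and 3 can be drawn from these three limits.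

Compound 4 `CO[C@@H]1[C@H](N(C)c2ncc(-c3c[nH]c4ccc(Cl)cc34)s2)C[C@H]2O[C@]1(C)n1c3ccccc3c3c4c(c5c6cc(Br)ccc6n2c5c31)C(=O)NC4` has not been measured in this assay. It differs from compound 3 by chloro in place of fluoro on an aromatic carbon, the same change as the one recorded in chloro in place of fluoro on an aromatic carbon, with the place described in identical words. Compound 4 is expected to show an estimated step that the limit leaves unreadable from compound 3 to compound 4 in this assay. That expectation rests on compound 3 sitting at > 10000 nM and on all three measured values sharing (the limit of > 10000 nM in this assay, at which 3 of the 3 values shown sit). In this assay compound 4 is therefore estimated at 20000 nM, with an expected range from 8000 nM to 60000 nM.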

Compound 4, half-maximal inhibitory concentration: > 10000 nM
Compound 4: a limit, no number (the forecaster's own chance of this, stated with the estimate: 85%); the middle value does not contradict the limit.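

In this assay compound 4 gives > 10000 nM, again only a limit, and no new step can be read from compound 2 or compound 3 to compound 4: the limit of > 10000 nM in this assay, at which 4 of the 4 values shown sit.

Left open is whether chloro in place of fluoro or bromo in place of hydrogen changes the value at all, and how compound 1, compound 2, compound 3 and compound 4 order in this assay.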